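The compounds below may be only part of what the source reports. "The series", "measured", "known", "first", "only" and "open" are said of these compounds alone.

Measured in a functional assay on cells (Platelet, Homo sapiens) for inhibition; a lower number here means a stronger inhibitor, a higher number a weaker inhibitor:
- Compound 1 `CCOC(=O)c1ccc(-c2nn(C)c3ccccc23)cc1`: > 10000 nM, a limit.
- Compound 2 `CCOC(=O)c1ccc(-c2nn(Cc3cccc(OC)c3)c3ccccc23)cc1`: > 10000 nM, a limit.
- Compound 3 `CCOC(=O)c1ccc(-c2nn(CC)c3ccccc23)cc1`: > 10000 nM, a limit.

Compound 3 offers no number to build on, since its > 10000 nM is a limit. The same is true of the other two compounds, as the limit of > 10000 nM in this assay, at which 3 of the 3 values shown sit, shows.

Compound 4 `CCCCn1nc(-c2ccc(C(=O)OCC)cc2)c2ccccc21` carries ethyl in place of hydrogen on a saturated chain carbon, two bonds along the chain from an aromatic nitrogen. Cut one bond further out, the same difference reads ethyl to butyl.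

Three measured steps change the same chain. The closest is a step that the two limits leave unreadable from compound 1 to compound 3. The larger changes are a step that the two limits leave unreadable from compound 1 to compound 2 and a step that the two limits leave unreadable from compound 2 to compound 3. None of them gives a size, but even the 3-methoxyphenyl group of compound 2, with its > 10000 nM, did not bring a value inside the limit. A readable gain in this assay is therefore not expected from the longer chain, and no step beyond the scatter is expected.

The expected step is a step that the limit leaves unreadable from compound 3 to compound 4.

Compound 4 is estimated at 15000 nM, with an expected range from 6000 nM to 40000 nM.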

Compound 4, half-maximal inhibitory concentration: > 10000 nM
Compound 4: a limit, no number (the forecaster's own chance of this, stated with the estimate: 85%); the middle value is on the limit's open side.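

The steps to compound 4 from compound 1, compound 2 and compound 3 cannot be read, because all four compounds give only a limit: the limit of > 10000 nM in this assay, at which 4 of the 4 values shown sit.

The compounds shown leave open whether any change to the shared core gives a measurable value in this assay.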